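The compounds below may be only part of what the source reports. "The series", "measured", "known", "first", "only" and "open" are said of these compounds alone.

Three compounds in this set share one core and differ only in the group on the aryl oxygen. Compound 1 `Nc1ccc2cccc(OC3CCCCCC3)c2n1` gives 137 nM in an assay on cells with melanin-concentrating hormone receptor 1 (Homo sapiens) as the target, read by radioligand binding; a lower number here means a stronger inhibitor, a higher number a weaker inhibitor. Compound 2 `CCCC(C)Oc1cccc2ccc(N)nc12` gives 105 nM in this assay, the lowest of the three numbers, though its gap to compound 1 lies within the scatter. Compound 3 `CC1CCCC(Oc2cccc3ccc(N)nc23)C1` gives 640 nM in this assay, a gap from compound 2 beyond the scatter. Compound 4 `CC(C)OCCOc1cccc2ccc(N)nc12` has not been measured. It differs from compound 2 in one place: 2-isopropoxyethyl in place of 1-methylbutyl on an oxygen on an aromatic ring. Among the compounds with values here, no measured pair covers a change of this kind; compound 3 shows only that another group on this oxygen can weaken binding. For compound 4 a modest rise in number is expected in this assay, a 2.4-fold higher number from compound 2 to compound 4 (0.38 log units; beyond the scatter). Compound 4 is estimated at 250 nM, between 80 nM and 800 nM.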

Compound 4, half-maximal inhibitory concentration: > 2000 nM
Compound 4: a limit, no number; the forecaster's own chance of this, stated with the estimate: 3%; middle value at least 8.0-fold (0.90 log units) from the limit.
By their numbers in this assay, from the lowest: compounds 2 and 1 (each within the scatter of the next); then compound 3. At a limit, above all of these: compound 4.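

In this assay, 2-isopropoxyethyl in place of 1-methylbutyl on an oxygen on an aromatic ring gives an at least 19-fold higher number from compound 2 to compound 4 (1.27 log units; beyond the scatter), a large step. Compound 4 reads only as a limit, not a number: the limit of > 2000 nM in this assay, at which 1 of the 4 values shown sits. Neither group has a ring, so at this position a chain without a ring does not by itself keep binding, and a swap of similar heavy-atom count can cost a large part of it.

Going by these compounds, whether the oxygen in the chain goes with the loss remains open. An all-carbon 4-methylpentyl group, or an amine in that chain, would test this.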